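A Nitrile on the Pyrimidine Ring of Compound 3

A few compounds are considered here, and "the series" means these few. Any claim that something is new, unique, unknown or untested is made for them only; others in the source may bear on it.

Of the compounds shown here, three sharing one core have been tested in a functional assay on NCI-H1975 cells (Homo sapiens) for antiproliferative activity, read by MTT assay, with a stated time of 72 h; a lower number here means a stronger inhibitor, a higher number a weaker inhibitor. Compound 1 `COc1cc(N(C)CCN(C)C)c(NC(=O)C=C(C)C)cc1Nc1nccc(-c2cn(C)c3ccccc23)n1` gives 5610 nM. Compound 2 `COc1cc(N(C)CCN(C)C)c(NC(=O)/C=C\C(C)C)cc1Nc1nccc(-c2cn(C)c3ccccc23)n1` gives 1820 nM, and compound 3 `CCC/C=C\C(=O)Nc1cc(Nc2nccc(-c3cn(C)c4ccccc34)n2)c(OC)cc1N(C)CCN(C)C` gives 1220 nM. Among these, compound 3 holds the lowest number; its gap to compound 2 lies within the scatter, so the two cannot be ordered, while the step of a 4.6-fold lower number from compound 1 to compound 3 (0.66 log units; beyond the scatter) lies beyond it.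

Compound 4 `CCC/C=C\C(=O)Nc1cc(Nc2ncc(C#N)c(-c3cn(C)c4ccccc34)n2)c(OC)cc1N(C)CCN(C)C` has not yet been measured in this assay. It differs from compound 3 by a single change: cyano in place of hydrogen on an aromatic carbon. Among the compounds with values here, none of the measured steps touches this part of the molecule. The steps of a 3.1-fold lower number from compound 1 to compound 2 (0.49 log units; beyond the scatter) and a 1.5-fold lower number from compound 2 to compound 3 (0.17 log units; within the scatter) both concern the chain on the carbonyl carbon, far from the aromatic ring that now carries the nitrile, so they offer no direct guide to the size or direction of this change.

Within the data shown here, with no comparable step to lean on, the expectation for compound 4 is a modest shift, most likely toward a lower number, expressed as a 1.7-fold lower number from compound 3 to compound 4 (0.24 log units; within the scatter). Compound 4 is therefore estimated at 700 nM, with a range from 150 nM to 3000 nM in this assay.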

Compound 4, half-maximal inhibitory concentration: 823 nM
Compound 4: middle estimate off by 1.2-fold (0.07 log units), on the low side, and the stated range covers the measured number.
By their numbers in this assay, from the lowest: compounds 4, 3 and 2 (each within the scatter of the next, the first and the last beyond it); then compound 1.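

In this assay, placing a cyano group on this aromatic carbon, ortho to a 1-methyl-1H-indol-3-yl group, gives a 1.5-fold lower number from compound 3 to compound 4 (0.17 log units; within the scatter), so the numbers for the two compounds cannot be told apart. Within the data shown here, this is the first measured step that touches the six-membered aromatic ring with 2 nitrogen, since all the earlier steps changed the chain on the carbonyl carbon, and it shows that swapping a hydrogen atom for these 2 heavy atoms at this carbon leaves the antiproliferative reading within the usual scatter in these cells. No available measurement explains why the number stays where it does.

At this carbon, the compounds shown carry only hydrogen or cyano, so it remains open what a chlorine atom, a methyl group, an amine or a carboxylic acid would do there. As far as these compounds go, it is also open whether cyano would give a similar step on the 2-methylprop-1-en-1-yl or 3-methylbut-1-en-1-yl chains of compound 1 and compound 2, since only the pent-1-en-1-yl chain of compound 3 has been paired with it here.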